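This account rests on a few compounds, and the source may have more. Where it says the series, first, only, none or still open, it means among the compounds named here.

Measured compounds:
- compound 1, `C=CCn1c(=O)/c(=C\c2cccc(Cl)c2)[nH]c(=O)/c1=C\c1ccccc1OC`, a functional assay on HL-60 cells (Homo sapiens) for cytotoxicity, read by CCK-8 assay, with a stated time of 72 h; on this read-out higher numbers stand for weaker inhibition and lower numbers for stronger inhibition: 4500 nM
- compound 2, `C=CCn1c(=O)/c(=C\c2cccc(Cl)c2Cl)[nH]c(=O)/c1=C\c1ccccc1OC`, this assay: 2000 nM
- compound 3, `C=CCn1c(=O)/c(=C\c2ccc(F)c(Br)c2)[nH]c(=O)/c1=C\c1ccccc1OC`, this assay: "not active" (no number reported)

Compound 1 and compound 2 share the core and differ only in one place; the step of a 2.3-fold lower number from compound 1 to compound 2 (0.35 log units; beyond the scatter) is modest but beyond the scatter. Compound 3 stands apart from both: in this assay compound 3 gave no number at all, only a report of no activity, so it cannot be ranked against compound 1 or compound 2 on a measured value.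

Compound 4, `C=CCn1c(=O)/c(=C\c2cc(F)ccc2C)[nH]c(=O)/c1=C\c1ccccc1OC`, is not yet measured. It differs from compound 3 by 5-fluoro-2-methylphenyl in place of 3-bromo-4-fluorophenyl on a double-bonded chain carbon bound to an aromatic carbon. For the measured compounds named here, no measured step bears directly on this change: the single measured step, from compound 1 to compound 2, concerns a different place on the ring and a different pair of groups. Going by the values given here, the only guide is that compound 3, with its 3-bromo-4-fluorophenyl group, showed no activity, while compound 1 and compound 2 with other substituted phenyl groups gave weak but measurable numbers. Compound 4 is therefore expected to sit in the weak range, with a real chance that this assay again reports no number. Compound 4 is estimated at 6000 nM, in a range from 1500 nM to 30000 nM.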

Compound 4, half-maximal inhibitory concentration: 2600 nM
Compound 4: the middle estimate sits 2.3-fold (0.36 log units) above what was measured; measured number inside the range.
By their numbers in this assay, from the lowest: compounds 2, 4 and 1 (each within the scatter of the next, the first and the last beyond it).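

In this assay, 5-fluoro-2-methylphenyl on a double-bonded chain carbon bound to an aromatic carbon gives a measurable number, as compound 4 reads 2600 nM while compound 3, with 3-bromo-4-fluorophenyl, was reported as not active, so the step between those two cannot be read. Against the chlorinated phenyl groups, the change gives a 1.3-fold higher number from compound 2 to compound 4 (0.11 log units; within the scatter) and a 1.7-fold lower number from compound 1 to compound 4 (0.24 log units; within the scatter) and so shows that, among these compounds, chlorine on this phenyl ring is not required for a measurable number. Compound 3 and compound 4 both carry fluorine and only compound 3 gave no number, and nothing available here accounts for that difference.

The compounds shown do not separate the role of the bromine in compound 3 from that of the arrangement of the groups on its ring. They also leave open how this position responds to a phenyl ring carrying something other than halogen or methyl, such as an amine or a carboxylic acid.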